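A few compounds are considered here, and "the series" means these few. Any claim that something is new, unique, unknown or untested is made for them only; others in the source may bear on it.

Compound 1, `O=S(=O)(/C=C\c1ncccc1F)c1ccccc1F`, gives 482 nM in an assay on U2OS cells for activation of nuclear factor erythroid 2-related factor 2 (Homo sapiens), read by beta-arrestin recruitment, with a stated time of 6 h; on this read-out lower numbers stand for an effect already at smaller amounts and higher numbers for an effect only at larger amounts of compound. Compound 2, `O=S(=O)(/C=C\c1ncccc1Cl)c1ccccc1F`, gives 1030 nM in this assay; the change from compound 1 is chloro in place of fluoro on an aromatic carbon and the step is a 2.1-fold higher number from compound 1 to compound 2 (0.33 log units; beyond the scatter). Compound 3, `O=S(=O)(/C=C/c1ncccc1F)c1cccc(F)c1`, gives 474 nM in this assay, and its value and that of compound 1 lie within the scatter of each other. The difference between the core of compound 3 and the core of compound 1 is not broken down here. Among the compounds with values here, compound 4, `O=S(=O)(/C=C/c1ncccc1Cl)c1cccc(F)c1`, is not yet measured; it differs from compound 3 by chloro in place of fluoro on an aromatic carbon, the same change as the one made from compound 1 to compound 2. In this assay the expected step is a 2.1-fold higher number from compound 3 to compound 4 (0.32 log units; beyond the scatter), resting on the modest rise seen in a 2.1-fold higher number from compound 1 to compound 2 (0.33 log units; beyond the scatter). Compound 4 is accordingly expected to give about 1000 nM, within 550 nM to 2000 nM.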

Compound 4, half-maximal effective concentration: 84 nM
Estimate against measurement, compound 4: 12-fold (1.08 log units) above, and the stated range ends above it.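

In this assay, chloro in place of fluoro on an aromatic carbon gives a 5.6-fold lower number from compound 3 to compound 4 (0.75 log units; beyond the scatter), and the two cores do not share one step for this change: the same change on two cores in this assay, a 2.1-fold higher number (0.33 log units; beyond the scatter) from compound 1 to compound 2 and a 5.6-fold lower number (0.75 log units; beyond the scatter) from compound 3 to compound 4, 12-fold (1.08 log units) apart, beyond the scatter of two such steps
The change therefore cannot be carried as a fixed step between these two cores, as its direction differs from one to the other. This does not show which feature separating the core of compound 1 from the core of compound 3 goes with the reversal, and two pairs give no rule for any further core.

Still open, as far as these compounds go, is how bromo, methyl or nitrile on the same aromatic carbon would read on each core. Also open, from the compounds shown here alone, is whether the low number of compound 4 survives replacing its remaining fluoro group with chloro.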